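This account rests on a few compounds, and the source may have more. Where it says the series, first, only, none or still open, it means among the compounds named here.

Measured compounds in the series:

compound 1, `C=C1[C@@H](OC(C)=O)C[C@@H]2[C@](C)(COC=O)[C@H](OC(C)=O)CC[C@@]2(C)[C@@H]1C[C@@H](Nc1ccc(OC)cc1)C1=CCOC1=O` — in a functional assay on KB cells (Homo sapiens) for cytotoxicity, read by sulforhodamine B assay (on this read-out lower numbers stand for stronger inhibition and higher numbers for weaker inhibition), compound 1 gives 32700 nM
compound 2, `C=C1[C@@H](OC(C)=O)C[C@@H]2[C@](C)(COC=O)[C@H](OC(C)=O)CC[C@@]2(C)[C@@H]1C[C@@H](Nc1ccccc1)C1=CCOC1=O` — in this assay compound 2 gives 32100 nM

Compound 2 holds the lowest of the two numbers, but its nearest neighbour is compound 1, and the step of a 1.0-fold lower number from compound 1 to compound 2 (0.01 log units; within the scatter) lies within the scatter, so the two values cannot be ordered. The aromatic ring hanging from the anilino nitrogen has so far tolerated one change, hydrogen in place of methoxy on an aromatic carbon, without any shift in the read-out.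

Compound 3, `C=C1[C@@H](OC(C)=O)C[C@@H]2[C@](C)(COC=O)[C@H](OC(C)=O)CC[C@@]2(C)[C@@H]1C[C@@H](Nc1ccccc1F)C1=CCOC1=O`, is the next variation on that ring. It differs from compound 2 as follows: fluoro in place of hydrogen on an aromatic carbon.

Among the measured compounds shown here, the only measured step that bears on this change is the one from compound 1 to compound 2, also a single-atom swap on the same aromatic ring, and it did not move the number. On that basis a step of a 1.0-fold lower number from compound 2 to compound 3 (0.02 log units; within the scatter) is expected, that is, nothing beyond the scatter in either direction. Compound 3 is therefore expected at about 31000 nM, with a plausible range from 13000 nM to 75000 nM.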

Compound 3, half-maximal inhibitory concentration: 29000 nM
Compound 3: the middle estimate sits 1.1-fold (0.03 log units) above what was measured; the measured number falls inside the stated range.
By their numbers in this assay, from the lowest: compounds 3, 2 and 1 (each within the scatter of the next).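

In this assay, among the compounds shown here, the step of a 1.1-fold lower number from compound 2 to compound 3 (0.04 log units; within the scatter) extends what the earlier compounds showed: the aromatic ring on the amine nitrogen also accepts fluoro in place of hydrogen on an aromatic carbon ortho to a large group, with no change beyond the scatter, whereas compounds 1 and 2 covered only 4-methoxyphenyl and phenyl. The step of a 1.1-fold lower number from compound 1 to compound 3 (0.05 log units; within the scatter) shows the same for 2-fluorophenyl in place of 4-methoxyphenyl on an amine nitrogen, so these two substituents, at different places on the ring, give values that cannot be told apart, and all three compounds stay together within the scatter. Nothing available explains why these changes on the ring leave the read-out where it is.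

Still open, on these data alone, is whether a larger or charged group on this ring, such as trifluoromethyl, a carboxylic acid or an amine, would give a number beyond the scatter. Equally open, as far as these compounds go, is whether replacing the phenyl group on the amine nitrogen with a benzyl group or a longer alkyl chain would move the read-out at all.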